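Swapping Thiomorpholin-4-yl for Morpholin-4-yl on a Thiocarbonyl Carbon

The compounds below may be only part of what the source reports. "The series", "measured", "known", "first", "only" and "open" are said of these compounds alone.

Three compounds from one series have been run through a functional assay on MCF7 cells (Homo sapiens) for cytotoxicity, read by MTT assay, with a stated time of 72 h, tested at 30 uM; on this read-out higher numbers stand for more inhibition of growth at the one concentration tested and lower numbers for less inhibition of growth. Compound 2 `Cc1ccnc(/C(N)=N/NC(=S)N2CCSCC2)c1` gives 74.2% in this assay. Compound 1 `Cc1ccnc(/C(N)=N/NC(=S)N2CCOCC2)c1` differs from compound 2 by a single change, (morpholin-4-yl in place of thiomorpholin-4-yl on a thiocarbonyl carbon), and in this assay compound 1 gives 8.16%. That change made a step of a number 66 percentage points lower from compound 2 to compound 1 (beyond the scatter). Compound 3 `N/C(=N\NC(=S)N1CCSCC1)c1ccc(F)cn1` rests on a different core; the difference between the two cores is not broken down here. In this assay compound 3 gives 58.8%, which stands second of the three, beyond the scatter below compound 2 and beyond the scatter above compound 1.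

Compound 4 `N/C(=N\NC(=S)N1CCOCC1)c1ccc(F)cn1` has not yet been measured in this assay. It differs from compound 3 by morpholin-4-yl in place of thiomorpholin-4-yl on a thiocarbonyl carbon, and the place of that change is described in the same words as for the pair of compound 2 and compound 1, so it is the same change, seen twice among the compounds shown. Among the compounds with values here, the only measured example, the step from compound 2 to compound 1, was large and downward. On that basis the step from compound 3 to compound 4 is expected to be about a number 52.8 percentage points lower from compound 3 to compound 4 (beyond the scatter), limited by the floor of the read-out since compound 3 starts lower than compound 2 did. Compound 4 is therefore estimated to give about 6% in this assay, with a plausible range from 0% to 25%.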

Compound 4, percent growth inhibition at one concentration: 56.7%
For compound 4 the middle estimate is 50.7 percentage points below the measured one; the measured number lies above the stated range.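

On the core of compound 3, the replacement of thiomorpholin-4-yl by morpholin-4-yl on a thiocarbonyl carbon gives, in this assay, a step of a number 2.1 percentage points lower from compound 3 to compound 4 (within the scatter), so on this core the change has no effect that can be told from the scatter. The large loss of growth inhibition seen on the core of compound 2 therefore did not carry over to the core of compound 3, and the size of this step depends on the core it is made on: the same change on two cores in this assay, a number 66 percentage points lower (beyond the scatter) from compound 2 to compound 1 and a number 2.1 percentage points lower (within the scatter) from compound 3 to compound 4, 63.9 percentage points apart, beyond the scatter of two such steps

This rests on one pair of compounds per core, read at a single concentration, so it does not show which part of the two cores sets the difference, how the change would behave on any further core, or how the compounds would compare across a full range of concentrations.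

The compounds shown leave open whether a piperidin-1-yl or a 4-methylpiperazin-1-yl group on the same thiocarbonyl carbon would split the two cores in the same way. They also leave open whether a core carrying a chlorine atom or a methoxy group would follow compound 2 and compound 1 or compound 3 and compound 4.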